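Ester tail: cyclopropylmethyl to cyclobutylmethyl

The compounds below may be only part of what the source reports. "The series", "measured", "known", "first", "only" and "open" are said of these compounds alone.

Values in an assay on membranes from CHO cells for displacement of a labelled ligand from adenosine receptor A1 (Homo sapiens), read by scintillation counting, with a stated time of 60 min, tested at 1 uM; a lower number here means less inhibition, a higher number more inhibition at the concentration tested (going by the name of the read-out):
compound 1 `CC1=C(C(=O)OCc2ccccc2)C(c2ccoc2)NC(=O)N1`: 41%
compound 2 `CC1=C(C(=O)C2CC2)C(c2ccoc2)NC(=O)N1`: 1%
compound 3 `CC1=C(C(=O)OCC2CC2)C(c2ccoc2)NC(=O)N1`: 29%

Compound 3 stands second highest of the three numbers. Its nearest neighbour is compound 1, the step of a number 12 percentage points lower from compound 1 to compound 3 (beyond the scatter) being beyond the scatter; furthest is compound 2, the step of a number 28 percentage points higher from compound 2 to compound 3 (beyond the scatter) also beyond the scatter.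

Compound 4 `CC1=C(C(=O)OCC2CCC2)C(c2ccoc2)NC(=O)N1` is not yet measured. It differs from compound 3 in one place: cyclobutyl in place of cyclopropyl on a saturated chain carbon bound to an oxygen next to a carbonyl group.

Going by the values given here, only one measured step touches the same place, a number 12 percentage points lower from compound 1 to compound 3 (beyond the scatter), and it was modest for a change that swaps phenyl for cyclopropyl. The step of a number 28 percentage points higher from compound 2 to compound 3 (beyond the scatter) alters the carbonyl carbon rather than the saturated chain carbon and gives no direct guide. Cyclopropyl to cyclobutyl is a smaller change in what is counted than phenyl to cyclopropyl, so in this assay a step no larger than the scatter is expected, if anything upward toward the number of compound 1.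

Compound 4 is therefore estimated at 35%, with a range of 20% to 50%, corresponding to an expected step of a number 6 percentage points higher from compound 3 to compound 4 (within the scatter).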

Compound 4, a percentage reported as inhibition, at one concentration (the size of the read-out at that concentration, not a potency): 46%
Compound 4: the middle estimate sits 11 percentage points below what was measured, within the range that was stated.
By their numbers in this assay, from the lowest: compound 2; then compound 3; then compounds 1 and 4 (each within the scatter of the next).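

In this assay, the swap of cyclopropyl for cyclobutyl on the saturated chain carbon bound to an oxygen is not silent, with a number 17 percentage points higher from compound 3 to compound 4 (beyond the scatter), so this place responds to a change as small as this one. Cyclobutyl and phenyl cannot be told apart here, with a number 5 percentage points higher from compound 1 to compound 4 (within the scatter), so among these esters an aromatic ring is not needed to reach this level, and compound 3 with its cyclopropyl is the one that falls short. The gap to the carbonyl-linked cyclopropyl of compound 2 now widens, with a number 45 percentage points higher from compound 2 to compound 4 (beyond the scatter), and no measured evidence accounts for any of these steps.

The compounds shown leave open whether cyclopentylmethyl or a longer straight chain at this place would hold the number. Also open, on these data alone, is how a tail carrying an amine or a carboxylic acid would read, and the single-concentration read-out gives no potency for any of these esters.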